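A few compounds are considered here, and "the series" means these few. Any claim that something is new, unique, unknown or untested is made for them only; others in the source may bear on it.

Compound 1 `CN(C)CCn1cnnc1-c1cc(Oc2ccc(NC(=O)Nc3cccc(C(F)(F)F)c3)cc2F)ccn1`: 77.7%
Compound 2 `CN(C)CCn1cnnc1-c1cc(Oc2ccc(NC(=O)Nc3ccccc3C(F)(F)F)cc2F)ccn1`: 43%
Compound 3 `CN(C)CCn1cnnc1-c1cc(Oc2ccc(NC(=O)Nc3ccc(F)c(F)c3)cc2F)ccn1`: 17.6%

In an assay on isolated protein for inhibition of proto-oncogene tyrosine-protein kinase receptor Ret (Homo sapiens), read by mobility shift assay, with a stated time of 1 h, tested at 10 uM (a higher number here means more inhibition at the concentration tested (going by the name of the read-out), a lower number less inhibition), compound 1 gives 77.7%, the highest of the three numbers. Compound 2 comes nearest, with a number 34.7 percentage points lower from compound 1 to compound 2 (beyond the scatter), and compound 3 lies furthest, with a number 60.1 percentage points lower from compound 1 to compound 3 (beyond the scatter). Between those two, a number 25.4 percentage points lower from compound 2 to compound 3 (beyond the scatter).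

Compound 4 `CCN(CC)CCn1cnnc1-c1cc(Oc2ccc(NC(=O)Nc3cccc(C(F)(F)F)c3)cc2F)ccn1` differs from compound 1 in a single place: diethylamino in place of dimethylamino on a saturated chain carbon, two bonds along the chain from an aromatic nitrogen. Among the compounds with values here, every measured step so far swaps the aryl group on the amide-type nitrogen at the far end of the molecule, and none of them alters the 2-(dimethylamino)ethyl chain on the triazole. Within the data shown here, no measured step therefore bears directly on the change from compound 1 to compound 4, and the large swings seen between compounds 1, 2 and 3 give no guide to it. With nothing in the data pointing either way, the expectation for compound 4 is a step no larger than the scatter, in no preferred direction. Compound 4 is estimated at 75%, within a range from 55% to 90%, which corresponds to an expected step of a number 2.7 percentage points lower from compound 1 to compound 4 (within the scatter).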

Compound 4, a percentage reported as inhibition, at one concentration (the size of the read-out at that concentration, not a potency): 72.1%
Beside the measured number, compound 4's estimate is 2.9 percentage points above it; low and high end bracket the measured number.
By their numbers in this assay, from the lowest: compound 3; then compound 2; then compounds 4 and 1 (each within the scatter of the next).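

In this assay, the first change shown away from the aryl group at the far end of the molecule gives only a small step, a number 5.6 percentage points lower from compound 1 to compound 4 (within the scatter). Whereas swapping that aryl group moved the number well beyond the scatter, going from 2-(dimethylamino)ethyl to 2-(diethylamino)ethyl, with 5 heavy atoms in the amine group instead of 3, produces no difference that can be told from the scatter. No supporting evidence accompanies this result to explain it.

A single swap between two open-chain amines shows little about how far this freedom extends. A ring amine such as morpholine or piperidine, a primary amine, or a longer chain could each behave differently, and a reading at one concentration does not settle whether compound 1 and compound 4 match in potency.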